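A few compounds are considered here, and "the series" means these few. Any claim that something is new, unique, unknown or untested is made for them only; others in the source may bear on it.

Working notes on the sulfonamide series, read in a functional assay on HT-29 cells (Homo sapiens) for antiproliferative activity, read by sulforhodamine B assay, with a stated time of 48 h; a higher number here means a weaker inhibitor, a lower number a stronger inhibitor.

Of the compounds shown here, three have numbers so far. Compound 1 `COc1ccc(NS(=O)(=O)c2ccc(N3CCNC3=O)cc2)cc1` gives 800 nM and stands highest of the three. Compound 2 `O=C1NCCN1c1ccc(S(=O)(=O)Nc2ccc(I)cc2)cc1` gives 650 nM; the step of a 1.2-fold lower number from compound 1 to compound 2 (0.09 log units; within the scatter) is within the scatter, so the two values are not separable. Compound 3 `Cc1cccc(NS(=O)(=O)c2ccc(N3CCNC3=O)cc2)c1` gives 110 nM, and the step of a 7.3-fold lower number from compound 1 to compound 3 (0.86 log units; beyond the scatter) is the largest gap from compound 1 in the set; likewise a 5.9-fold lower number from compound 2 to compound 3 (0.77 log units; beyond the scatter) sets compound 3 apart from compound 2.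

Compound 4 `O=C1NCCN1c1ccc(S(=O)(=O)Nc2ccc(Cl)cc2)cc1` has not yet been measured. It differs from compound 1 as follows: chloro in place of methoxy on an aromatic carbon. For the measured compounds named here, the step that bears most directly on this is the one from compound 1 to compound 2, where another halogen took the same place and the number moved only within the scatter. The steps to compound 3 change the substitution pattern of the ring rather than the group at this place, so they carry less weight here. Accordingly no step beyond the scatter is expected from compound 1 to compound 4: the expected step is a 1.1-fold lower number from compound 1 to compound 4 (0.06 log units; within the scatter). Compound 4 is therefore estimated at 700 nM, with a range from 350 nM to 1400 nM.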

Compound 4, half-maximal inhibitory concentration: 220 nM
The estimate for compound 4 lay 3.2-fold (0.50 log units) above the measured number; the whole stated range lies above it.
By their numbers in this assay, from the lowest: compounds 3 and 4 (each within the scatter of the next); then compounds 2 and 1 (each within the scatter of the next).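

At the aromatic carbon para to a large group, the number does respond to the group placed there, which the earlier pair did not show: chloro gives a 3.6-fold lower number from compound 1 to compound 4 (0.56 log units; beyond the scatter) in this assay. Halogens cannot be treated as one class at this place, as chloro in place of iodo gives a 3.0-fold lower number from compound 2 to compound 4 (0.47 log units; beyond the scatter), although compounds 1 and 2 could not be separated. The 4-chlorophenyl group also reaches the range of the 3-methylphenyl group, with a 2.0-fold higher number from compound 3 to compound 4 (0.30 log units; within the scatter), so the two cannot be told apart here, and the low end of the series is not confined to compound 3.

No measured information accounts for the difference between chloro and iodo at this place. Going by these compounds, whether fluoro, bromo or an amine at the same carbon would read with compound 4 or with compounds 1 and 2 remains open.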